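Removing a hydroxy from a shared core: what to expect

A few compounds are considered here, and "the series" means these few. Any claim that something is new, unique, unknown or untested is made for them only; others in the source may bear on it.

Of the compounds shown here, three from one study have been tested in a functional assay on HL-60 cells (Homo sapiens) for antiproliferative activity, read by trypan blue exclusion (a higher number here means a weaker inhibitor of growth, a lower number a stronger inhibitor of growth), so far. Compound 1, with the structure `C=C1[C@H](O)C[C@@H]2[C@](C)(CO)[C@H](O)CC[C@@]2(C)[C@@H]1CCC1=CCOC1=O`, gives 22500 nM. Compound 2, with the structure `C=C1CC[C@@H]2[C@](C)(CO)[C@H](O)CC[C@@]2(C)[C@@H]1C[C@@H](O)[C@H]1C(=O)OC[C@H]1O`, gives 26600 nM in this assay. Compound 3, with the structure `C=C1CC[C@@H]2[C@](C)(CO[C@@H]3O[C@H](CO)[C@@H](O)[C@H](O)[C@H]3O)CCC[C@@]2(C)[C@@H]1CCC1=CCOC1=O`, gives 26700 nM. All three numbers sit within the usual scatter of one another, so compound 1 cannot be set apart from compound 2 or compound 3 on these data; the three simply behave alike.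

Compound 4, with the structure `C=C1CC[C@@H]2[C@](C)(CO)[C@H](O)CC[C@@]2(C)[C@@H]1CCC1=CCOC1=O`, has not yet been measured. It differs from compound 1 by one change: hydrogen in place of hydroxy on a saturated ring carbon. Within the data shown here, no pair of measured compounds here differs in a single place, so there is no measured step to lean on for this kind of change. Given that the three measured compounds, which differ from one another in several ways, all land so close together, the expectation for compound 4 is a step from compound 1 of about a 1.1-fold higher number from compound 1 to compound 4 (0.05 log units; within the scatter), essentially none beyond the scatter. Compound 4 is therefore estimated at 25000 nM in this assay, with a range from 8000 nM to 80000 nM.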

Compound 4, concentration for 50% growth inhibition: 25500 nM
Compound 4: the middle estimate sits 1.0-fold (0.01 log units) below what was measured; the measured number falls inside the stated range.
By their numbers in this assay, from the lowest: compounds 1, 4, 2 and 3 (each within the scatter of the next).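

Among these compounds, this is the first pair here that differs in one place only, so it gives a direct reading of one change in this assay: hydrogen in place of hydroxy on a saturated ring carbon of a six-membered non-aromatic ring of carbon only gives a 1.1-fold higher number from compound 1 to compound 4 (0.05 log units; within the scatter) and stays within the scatter. At this position, then, the hydroxy can leave, taking one hydrogen-bond donor and one hydrogen-bond acceptor with it, and compound 1 and compound 4 still cannot be told apart in growth inhibition. Nothing shown here offers a measured explanation of why the change leaves so little trace.

The compounds shown leave open whether a different group on this same ring carbon, such as an amine, a methoxy group or a carboxylic acid, would also read the same as hydrogen and hydroxy do. They also leave open whether swapping hydroxy for hydrogen at this position would read the same on a core that differs elsewhere, so this one pair describes only the core of compound 1.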